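Cyclohexyl in Place of Benzyl: Expected Cytotoxicity

This account rests on a few compounds, and the source may have more. Where it says the series, first, only, none or still open, it means among the compounds named here.

compound 1 `O=[N+]([O-])c1ccc(CSc2nnnn2C2CCCCC2)c([N+](=O)[O-])c1`: 17000 nM
compound 2 `O=[N+]([O-])c1cc(CSc2nnnn2Cc2ccccc2)cc([N+](=O)[O-])c1`: > 30000 nM

In an ADME assay on MDCK-II cells (Canis lupus familiaris) for cytotoxicity, read by MTT assay, with a stated time of 48 h (on this read-out higher numbers stand for weaker inhibition and lower numbers for stronger inhibition), compound 1 gives 17000 nM. Compound 2 reaches only a limit of the assay, > 30000 nM, so no number is known for it. Compound 2 thus stands at the limit of > 30000 nM in this assay, at which 1 of the 2 values shown sits, the weaker end of what is shown here. Compound 3 `O=[N+]([O-])c1cc(CSc2nnnn2C2CCCCC2)cc([N+](=O)[O-])c1` is compound 2 with one change: cyclohexyl in place of benzyl on an aromatic nitrogen. Among the measured compounds shown here, no measured pair isolates this change, so its size is not known from data. Compound 1 also carries cyclohexyl on an aromatic nitrogen, though its nitro groups are placed differently, and it gives a measured number where compound 2 gives only a limit. Compound 3 is therefore expected near 25000 nM, with a range from 10000 nM to 60000 nM. The step this estimate implies is an at least 1.2-fold lower number from compound 2 to compound 3 (0.07 log units; that floor lies within the scatter), expected to be small, toward somewhat stronger inhibition, and possibly within the scatter.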

Compound 3, half-maximal inhibitory concentration: > 30000 nM
Compound 3: a limit, no number; the forecaster's own chance of this, stated with the estimate: 40%; at least 1.2-fold (0.07 log units) between middle value and limit.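

Compound 2 and compound 3 both reach only a limit in this assay, so no step between them can be read: the limit of > 30000 nM in this assay, at which 2 of the 3 values shown sit.

The compounds shown leave open where the true values of compound 2 and compound 3 lie, and so whether cyclohexyl in place of benzyl on an aromatic nitrogen changes the read-out at all.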